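Aryl change on the ring nitrogen: compound 3 to compound 4

A few compounds are considered here, and "the series" means these few. Any claim that something is new, unique, unknown or untested is made for them only; others in the source may bear on it.

Values in a functional assay on MCF7 cells (Homo sapiens) for cytotoxicity, read by MTT assay, with a stated time of 72 h; on this read-out higher numbers stand for weaker inhibition and lower numbers for stronger inhibition:
- compound 1 `Cn1ccc2c(Oc3ccc(NC(=O)c4cc5cccnc5n(-c5ccc(F)cc5)c4=O)cc3F)ncnc21` gives 11900 nM
- compound 2 `Cn1ccc2c(Oc3ccc(NC(=O)c4cc5cccnc5n(-c5ccc(Br)cc5)c4=O)cc3F)ncnc21` gives 59400 nM
- compound 3 `O=C(Nc1ccc(Oc2ncnc3[nH]ccc23)c(F)c1)c1cc2cccnc2n(-c2ccc(F)cc2)c1=O` gives 9230 nM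

Compound 3 (9230 nM) sits at the low end of the three numbers, but it cannot be separated from its methylated counterpart: hydrogen in place of methyl on an aromatic nitrogen gives a 1.3-fold lower number from compound 1 to compound 3 (0.11 log units; within the scatter). Compound 2 (59400 nM) lies clearly higher than compound 3.

Compound 4 `O=C(Nc1ccc(Oc2ncnc3[nH]ccc23)c(F)c1)c1cc2cccnc2n(-c2ccc(C(F)(F)F)cc2Cl)c1=O` is unmeasured and carries 2-chloro-4-(trifluoromethyl)phenyl in place of 4-fluorophenyl on an aromatic nitrogen, that is, 2-chloro-4-(trifluoromethyl)phenyl in place of 4-fluorophenyl on an aromatic nitrogen. For the measured compounds named here, the only measured change on this aryl group is bromo in place of fluoro, which gives a 5.0-fold higher number from compound 1 to compound 2 (0.70 log units; beyond the scatter) and is beyond the scatter. That single step was seen with the methyl retained, and the step to compound 3 gives no sign that the methyl matters. Going by the values given here, no measured compound carries a chloro or trifluoromethyl group, so the guide is weak. A step of similar size towards a higher number is expected in this assay. The estimated change is a 3.0-fold higher number from compound 3 to compound 4 (0.48 log units; beyond the scatter). The estimate for compound 4 is 28000 nM, with an expected range from 9000 nM to 80000 nM.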

Compound 4, half-maximal inhibitory concentration: 214000 nM
Beside the measured number, compound 4's estimate is 7.6-fold (0.88 log units) below it; the whole stated range lies below it.
By their numbers in this assay, from the lowest: compounds 3 and 1 (each within the scatter of the next); then compound 2; then compound 4.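

In this assay, this aryl position on the ring nitrogen tolerates change poorly: the step from 4-fluorophenyl to 2-chloro-4-(trifluoromethyl)phenyl (a 23-fold higher number from compound 3 to compound 4 (1.37 log units; beyond the scatter)) is the largest in the series and runs in the same direction as the earlier bromo for fluoro step (a 5.0-fold higher number from compound 1 to compound 2 (0.70 log units; beyond the scatter)). Both changes on this aryl group therefore lead to weaker inhibition in the pairs shown, and neither pair contains a replacement that gives a lower number than the 4-fluorophenyl compound it is compared with. The new step replaces the fluoro with both a chloro and a trifluoromethyl group, so it cannot be divided between them, and no measurement here explains its size.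

The compounds shown leave open whether the chloro or the trifluoromethyl group accounts for most of the step, which aryl rings carrying either group alone would help settle. Also open, as far as these compounds go, are the effects of a plain phenyl ring, a methoxy group or an amine at this position, and whether methyl on the aromatic nitrogen of the core changes the step seen with the new aryl group.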